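This account rests on a few compounds, and the source may have more. Where it says the series, first, only, none or still open, it means among the compounds named here.

Among the measured compounds shown here, compound 1 `CC(C)(C)NCC#CCCC(=O)C(O)(c1ccccc1)C1CCCCC1` gives 4300 nM in a functional assay with Cavia porcellus as the target (on this read-out lower numbers stand for stronger inhibition and higher numbers for weaker inhibition), the highest number among the three compounds measured so far. Compound 2 `CC(C)N(C)CC#CCCC(=O)C(O)(c1ccccc1)C1CCCCC1` gives 267 nM in this assay, and compound 3 `CCN(CC#CCCC(=O)C(O)(c1ccccc1)C1CCCCC1)C(C)C` gives 217 nM. Both carry a tertiary amine where compound 1 carries (tert-butyl)amino, and the two steps are large: a 16-fold lower number from compound 1 to compound 2 (1.21 log units; beyond the scatter) and a 20-fold lower number from compound 1 to compound 3 (1.30 log units; beyond the scatter). The remaining step, a 1.2-fold lower number from compound 2 to compound 3 (0.09 log units; within the scatter), carries no information beyond the scatter. Compound 4 `CCCCN(CC#CCCC(=O)C(O)(c1ccccc1)C1CCCCC1)CCCC` repeats the same kind of exchange with a longer pair of alkyl groups: dibutylamino in place of (tert-butyl)amino on a saturated chain carbon bound to a triple-bonded carbon. The steps from compound 1 to compound 2 and to compound 3 bear directly on this change; each lies well beyond the scatter and both run toward a lower number, so a step of similar size in the same direction is expected in this assay. Whether dibutylamino moves the number further than the groups of compound 2 and compound 3 cannot be told from the data in hand. For compound 4 the expected step is a 14-fold lower number from compound 1 to compound 4 (1.16 log units; beyond the scatter). Compound 4 is estimated at 300 nM, with a range from 90 nM to 1500 nM.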

Compound 4, antagonist equilibrium constant: > 5000 nM
Compound 4: only a limit was reported; the forecaster's own chance of this, stated with the estimate: 5%; middle value at least 16-fold (1.22 log units) away from the limit.
By their numbers in this assay, from the lowest: compounds 3 and 2 (each within the scatter of the next); then compound 1. At a limit, above all of these: compound 4.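

In this assay compound 4 is reported only as a limit, not as a number: the limit of > 5000 nM in this assay, at which 1 of the 4 values shown sits. A tertiary amine at this place, on a saturated chain carbon bound to a triple-bonded carbon, therefore does not by itself give the lower number, as dibutylamino stands apart from ethyl(isopropyl)amino and isopropyl(methyl)amino, with an at least 23-fold higher number from compound 3 to compound 4 (1.36 log units; beyond the scatter) and an at least 18-fold higher number from compound 2 to compound 4 (1.27 log units; beyond the scatter). Against the secondary amine the step is an at least 1.1-fold higher number from compound 1 to compound 4 (0.06 log units; that floor lies within the scatter), so compound 4 shows none of the drop seen for the other two tertiary amines, though its floor does not separate it from compound 1.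

As far as these compounds go, how far compound 4 lies past its limit remains open. Also open, from the compounds shown here alone, is whether diethylamino, dipropylamino or a piperidine at this place would keep the lower number or lose it.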